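Methyl for Chloro in a Weak Cytotoxic Pair

The source may hold more compounds than are shown below. What is called first, only, known or untested is meant among the compounds shown, and "the series" means these compounds.

Compound 1 `CC(=O)c1nn(-c2ccc(C)cc2)/c(=N/c2nc(-c3c(C)n(C)n(-c4ccccc4)c3=O)cs2)s1` gives 56800 nM in a functional assay on MCF7 cells (Homo sapiens) for cytotoxicity, read by sulforhodamine B assay, with a stated time of 72 h; a higher number here means a weaker inhibitor, a lower number a stronger inhibitor. Compound 2 `CCOC(=O)c1nn(-c2ccc(Cl)cc2)/c(=N/c2nc(-c3c(C)n(C)n(-c4ccccc4)c3=O)cs2)s1` stands only at a limit: in this assay compound 2 returns > 100000 nM, which is a limit of the assay rather than a number, as noted in the limit of > 100000 nM in this assay, at which 1 of the 2 values shown sits. Compound 3 `CCOC(=O)c1nn(-c2ccc(C)cc2)/c(=N/c2nc(-c3c(C)n(C)n(-c4ccccc4)c3=O)cs2)s1` differs from compound 2 by methyl in place of chloro on an aromatic carbon. Within the data shown here, with no step between measured compounds to lean on, the expected step of a number no higher from compound 2 to compound 3 (the limit leaves the size open) is small and within the usual scatter. Compound 3 is therefore estimated at 100000 nM, with a range from 40000 nM to 250000 nM.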

Compound 3, half-maximal inhibitory concentration: > 100000 nM
Compound 3: only a limit was reported; the forecaster's own chance of this, stated with the estimate: 60%; the middle value sits exactly at the limit.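

Ethoxy in place of methyl on a carbonyl carbon goes with an at least 1.7-fold higher number from compound 1 to compound 3 (0.24 log units; that floor lies within the scatter) in this assay, the first step shown at that place, though its floor lies within the usual scatter. With 4-methylphenyl in place of 4-chlorophenyl, compound 3 sits at the same limit of the assay as compound 2, so the step between them cannot be read: the limit of > 100000 nM in this assay, at which 2 of the 3 values shown sit.

From the compounds shown here alone, how far either place can move the number stays open. So does whether an amine or a carboxylic acid in place of ethoxy would give a value inside the range of this assay.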